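This account rests on a few compounds, and the source may have more. Where it says the series, first, only, none or still open, it means among the compounds named here.

Measured in a functional assay on HCT-116 cells (Homo sapiens) for cytotoxicity, read by sulforhodamine B assay, with a stated time of 48 h; a lower number here means a stronger inhibitor, a higher number a weaker inhibitor
compound 1 `CCCCNC(=O)N1Cc2c(NC(=O)c3ccc(F)cc3)nn(C(=O)c3ccccc3)c2C1` gives 30800 nM
compound 2 `CC(=O)n1nc(NC(=O)c2ccccc2)c2c1CN(C(=O)c1cccc(Cl)c1)C2` gives 17400 nM

Compound 2 stands within the scatter of compound 1, so these two values do not separate. Compound 3 (`CC(=O)n1nc(NC(=O)c2ccccc2)c2c1CN(C(=O)c1ccncc1)C2`) carries pyridin-4-yl in place of 3-chlorophenyl on a carbonyl carbon. The two measured compounds differ in more than one place, so the data give no measured size for this change. The expectation is a small rise in the number, little beyond the scatter (a 1.4-fold higher number from compound 2 to compound 3 (0.16 log units; within the scatter)). For compound 3 the estimated value is 25000 nM (expected range 9000 nM to 65000 nM).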

Compound 3, half-maximal inhibitory concentration: 10000 nM
Beside the measured number, compound 3's estimate is 2.5-fold (0.40 log units) above it, and the stated range covers the measured number.
By their numbers in this assay, from the lowest: compounds 3, 2 and 1 (each within the scatter of the next, the first and the last beyond it).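

The carbonyl carbon on the amide-type ring nitrogen now has its first one-place reading in this assay, with a 1.7-fold lower number from compound 2 to compound 3 (0.24 log units; within the scatter) on replacing 3-chlorophenyl with pyridin-4-yl. Neither the loss of the chlorine nor the entry of a ring nitrogen with one hydrogen-bond acceptor separates the two values at this position. No measurement at hand explains the size of this step.

Open, on these data alone, is whether pyridin-3-yl, an aliphatic amine or a carboxylic acid on this carbonyl carbon would move the number beyond the scatter. Also open, as far as these compounds go, is whether a longer chain here would do so.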